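Urea to amide on a pyrazole anilide series

The compounds below may be only part of what the source reports. "The series", "measured", "known", "first", "only" and "open" are said of these compounds alone.

Measured compounds:
compound 1, `COc1cc(Cl)cc(-c2nn(-c3cccc(NC(=O)c4ccc(Cl)c(Cl)c4)c3)cc2-c2ccncc2)c1`, 46%
compound 2, `COc1cc(Cl)cc(-c2nn(-c3cccc(NC(=O)Nc4ccc(Cl)c(C(F)(F)F)c4)c3)cc2-c2ccncc2)c1`, -29.1%
compound 3, `COc1cc(Cl)cc(-c2nn(-c3cccc(NC(=O)Nc4cccc(C(F)(F)F)c4)c3)cc2-c2ccncc2)c1`, -14.2%

Compound 3 stands second highest of the three numbers in a functional assay on RPMI-8226 cells (Homo sapiens) for inhibition, read by sulforhodamine B assay, with a stated time of 48 h, tested at 10 uM; on this read-out lower numbers stand for a stronger effect and higher numbers for a weaker effect at the one concentration tested. Its nearest neighbour is compound 2, which sits lower by a number 14.9 percentage points higher from compound 2 to compound 3 (beyond the scatter), and its furthest is compound 1, which sits higher by a number 60.2 percentage points lower from compound 1 to compound 3 (beyond the scatter).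

Compound 4, `COc1cc(Cl)cc(-c2nn(-c3cccc(NC(=O)c4cccc(C(F)(F)F)c4)c3)cc2-c2ccncc2)c1`, has not yet been measured in this assay. It differs from compound 3 in a single place: 3-(trifluoromethyl)phenyl in place of (3-(trifluoromethyl)phenyl)amino on a carbonyl carbon. The measured steps that bear on this change are those from compound 1 to the two ureas, where a number 75.1 percentage points lower from compound 1 to compound 2 (beyond the scatter) and a number 60.2 percentage points lower from compound 1 to compound 3 (beyond the scatter); both are large, and both pair a shift from a carbonyl bearing an aryl to a carbonyl bearing an arylamino with a change in the aryl substituents. Compound 4 keeps the aryl substituents of compound 3 and reverses only the linker, so a large step is expected in the opposite direction, towards the number of compound 1.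

Compound 4 is therefore estimated to give 30% in this assay, with a likely range from -5% to 60%. The step from compound 3 to compound 4 is expected to be a number 44.2 percentage points higher from compound 3 to compound 4 (beyond the scatter).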

Compound 4, a percentage reported as activity, at one concentration (the size of the read-out at that concentration, not a potency): 31.5%
Compound 4: middle estimate off by 1.5 percentage points, on the low side; measured number inside the range.
By their numbers in this assay, from the lowest: compound 2; then compound 3; then compound 4; then compound 1.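

In this assay, within the data shown here, the step of a number 45.7 percentage points higher from compound 3 to compound 4 (beyond the scatter) isolates the link on the carbonyl carbon with the 3-(trifluoromethyl)phenyl ring held constant, and it shows that losing the amino nitrogen alone gives a large move towards a weaker effect, which the earlier steps could not show because each also changed the ring substituents. The two other new steps place this change in context: a number 60.6 percentage points higher from compound 2 to compound 4 (beyond the scatter), with the chloro group also gone, while a number 14.5 percentage points lower from compound 1 to compound 4 (beyond the scatter), so exchanging the ring substituents between the two amides gives only a modest step, and among these four compounds both amides give higher numbers than both ureas, with none going against that order. No available evidence says why the link has this effect.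

The compounds shown leave open whether the same link effect holds with the 3,4-dichlorophenyl and 4-chloro-3-(trifluoromethyl)phenyl rings, since neither ring appears here on both an amide and a urea. They also leave open how a thiourea or a sulfonamide would read at this position.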